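Swapping the ring on the chain of compound 1

A few compounds are considered here, and "the series" means these few. Any claim that something is new, unique, unknown or untested is made for them only; others in the source may bear on it.

Measured compounds:
compound 1 `CC(C)C(Cc1ncc[nH]1)c1ccc(-c2ccc3cccc(F)c3c2)[nH]c1=O`: 11 nM
compound 2 `CCn1ncc2c(F)cc(-c3ccc(C(CC)(CC)c4nnc[nH]4)c(=O)[nH]3)cc21`: 17 nM
compound 3 `CCn1ncc2c(F)cc(-c3ccc(C(CC)(CC)c4nnc(C)[nH]4)c(=O)[nH]3)cc21`: 34 nM

In an assay on CHO cells for displacement of a labelled ligand from prostaglandin E2 receptor EP3 subtype (Homo sapiens), read by radioligand binding (on this read-out lower numbers stand for stronger inhibition and higher numbers for weaker inhibition), compound 1 gives the lowest of the three numbers. Its nearest neighbour is compound 2, whose value lies within the scatter of it, while compound 3 sits beyond the scatter. Among the measured compounds shown here, the only step within the set, a 2.0-fold higher number from compound 2 to compound 3 (0.30 log units; within the scatter), concerns a methyl on an aromatic carbon in compounds that carry a different group on the chain and therefore does not bear directly on the change considered here.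

Compound 4 `CC(C)C(Cc1noc(=O)[nH]1)c1ccc(-c2ccc3cccc(F)c3c2)[nH]c1=O` differs from compound 1 in one place: a group of 6 heavy atoms (2 carbon, 2 nitrogen, 2 oxygen; one five-membered aromatic ring with 3 hetero atoms) in place of a group of 5 heavy atoms (3 carbon, 2 nitrogen; one five-membered aromatic ring with 2 hetero atoms), on a saturated chain carbon, two bonds along the chain from an aromatic carbon. For the measured compounds named here, no measured pair shows what such a swap does in this assay, so the expectation rests on compound 1 alone and carries a wide range. Because compound 1 gives 11 nM, the estimate for compound 4 is 20 nM, between 5 nM and 80 nM, which would mean an expected 1.8-fold higher number from compound 1 to compound 4 (0.26 log units; within the scatter).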

Compound 4, inhibition constant: 34 nM
Beside the measured number, compound 4's estimate is 1.7-fold (0.23 log units) below it; the measured number falls inside the stated range.
By their numbers in this assay, from the lowest: compounds 1, 2, 3 and 4 (each within the scatter of the next, the first and the last beyond it).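

Among the compounds shown here, at the saturated chain carbon, two bonds along the chain from an aromatic carbon, this assay now gives a first direct reading of a ring swap: a 3.1-fold higher number from compound 1 to compound 4 (0.49 log units; beyond the scatter) is a modest step, yet it lies beyond the scatter, so the two rings are not interchangeable at this place. The change to a five-membered aromatic ring with 3 hetero atoms and a double bond outside the ring costs something, but compound 4 still gives a measurable number of the same modest order as the other compounds shown. No measurement among the data accounts for this step. The compounds shown leave open how a carboxylic acid or an amine would read at this same place. They also leave open whether the swap would produce a step of similar size on the core of compound 2.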